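The source may hold more compounds than are shown below. What is called first, only, known or untested is meant among the compounds shown, and "the series" means these compounds.

Compound 2 `Cc1ccc(-c2nnc(-c3ccc(CN4CCN(C)CC4)c(C(F)(F)F)c3)o2)cc1Nc1nccc(-c2cccnc2)n1` stands lowest of the three numbers measured in a functional assay on K562 cells (Homo sapiens) for inhibition, read by MTT assay, with a stated time of 72 h (on this read-out lower numbers stand for stronger inhibition and higher numbers for weaker inhibition), at 510 nM. Compound 1 `Cc1ccc(-c2nnc(-c3ccc(CN4CCN(C)CC4)cc3)o2)cc1Nc1nccc(-c2cccnc2)n1` gives 4900 nM, and the step of a 9.6-fold lower number from compound 1 to compound 2 (0.98 log units; beyond the scatter) lies beyond the scatter. Compound 3 `Cc1ccc(-c2nnc(-c3ccc(CN4CCN(CCN=C=S)CC4)cc3)o2)cc1Nc1nccc(-c2cccnc2)n1` gives 920 nM, a number within the scatter of compound 2. Compound 4 `C=CC(=O)NCCN1CCN(Cc2ccc(-c3nnc(-c4ccc(C)c(Nc5nccc(-c6cccnc6)n5)c4)o3)cc2C(F)(F)F)CC1` differs from compound 2 by ((vinylcarbonyl)amino)methyl in place of hydrogen on a saturated chain carbon bound to an amine nitrogen in a ring. The measured step that bears on this change is a 5.3-fold lower number from compound 1 to compound 3 (0.73 log units; beyond the scatter), in which a chain likewise entered on the saturated chain carbon bound to the amine nitrogen in the ring. That step was modest, and compound 2 already holds the gain of a 9.6-fold lower number from compound 1 to compound 2 (0.98 log units; beyond the scatter), so a smaller step is expected here, namely a 2.3-fold lower number from compound 2 to compound 4 (0.37 log units; beyond the scatter). Compound 4 is thus estimated to give 220 nM, with a range from 70 nM to 700 nM.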

Compound 4, half-maximal inhibitory concentration: 600 nM
Beside the measured number, compound 4's estimate is 2.7-fold (0.44 log units) below it, within the range that was stated.
By their numbers in this assay, from the lowest: compounds 2, 4 and 3 (each within the scatter of the next); then compound 1.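

At this position, on a saturated chain carbon bound to an amine nitrogen in a ring, a 1.2-fold higher number from compound 2 to compound 4 (0.07 log units; within the scatter) shows that in this assay the trifluoromethyl compound keeps its number when ((vinylcarbonyl)amino)methyl enters. The earlier chain step, a 5.3-fold lower number from compound 1 to compound 3 (0.73 log units; beyond the scatter), was beyond the scatter, but it involved another chain on a compound without trifluoromethyl. No evidence here accounts for this difference.

The compounds shown leave open whether ((vinylcarbonyl)amino)methyl would shift the number without trifluoromethyl. They also leave open how a carboxylic acid or a longer chain would read here.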